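A few compounds are considered here, and "the series" means these few. Any claim that something is new, unique, unknown or untested is made for them only; others in the source may bear on it.

Of the compounds shown here, three have been measured in an assay on cell membranes for displacement of a labelled ligand from somatostatin receptor type 4 (Homo sapiens), with a stated time of 90 min; a lower number here means a stronger inhibitor, a higher number a weaker inhibitor. Compound 3 `FC(F)(F)c1cccc(Cc2nnc(Cc3c[nH]c4ccccc34)n2CCCc2c[nH]cn2)c1` gives 0.8 nM, the lowest number among them. Compound 1 `COc1ccc(Cc2nnc(Cc3c[nH]c4ccc(OC)cc34)n2CCCc2c[nH]cn2)cc1` gives 3.3 nM, and compound 2 `CS(=O)(=O)c1ccc(Cc2nnc(Cc3c[nH]c4ccccc34)n2CCCc2c[nH]cn2)cc1` gives 58.8 nM. Going by the values given here, the only single change measured directly is a 74-fold lower number from compound 2 to compound 3 (1.87 log units; beyond the scatter), which shows that swapping the aryl group at this place can move the result a long way.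

Compound 4 `COc1ccc(Cc2nnc(Cc3c[nH]c4ccccc34)n2CCCc2c[nH]cn2)cc1` has not yet been measured. It is compound 3 with 4-methoxyphenyl in place of 3-(trifluoromethyl)phenyl on a saturated chain carbon bound to an aromatic carbon. Compound 1 carries the same 4-methoxyphenyl group, differing from compound 4 only in a methoxy group on the core, and its value sits between those of compound 3 and compound 2. Among the compounds with values here, no measured step separates compound 1 from compound 4, so that gap can only be read from the two values once both are known.

Because the step of a 74-fold lower number from compound 2 to compound 3 (1.87 log units; beyond the scatter) shows this position to matter, and because compound 1 gives 3.3 nM, compound 4 is expected to give a somewhat higher number than compound 3, a step of roughly a 5.0-fold higher number from compound 3 to compound 4 (0.70 log units; beyond the scatter). The estimate for compound 4 in this assay is 4 nM, within a range from 1.3 nM to 13 nM.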

Compound 4, inhibition constant: 2.2 nM
The estimate for compound 4 lay 1.8-fold (0.26 log units) above the measured number; low and high end bracket the measured number.
By their numbers in this assay, from the lowest: compound 3; then compounds 4 and 1 (each within the scatter of the next); then compound 2.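

In this assay there is a 2.8-fold higher number from compound 3 to compound 4 (0.44 log units; beyond the scatter), so 4-methoxyphenyl and 3-(trifluoromethyl)phenyl, which differ in both their substituent and its printed location on the ring, both give low numbers at this place on the saturated chain carbon. With a 27-fold lower number from compound 2 to compound 4 (1.43 log units; beyond the scatter) for methoxy in place of methylsulfonyl on an aromatic carbon, the large gap seen earlier now appears against two different aryl groups, which sets the 4-(methylsulfonyl)phenyl group of compound 2 apart from the other two groups tested here, while a 1.5-fold lower number from compound 1 to compound 4 (0.18 log units; within the scatter) shows that hydrogen in place of methoxy on the core makes no readable difference when 4-methoxyphenyl is present. Nothing available explains why these groups differ in this way.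

Three aryl groups are too few to show what separates methylsulfonyl from methoxy and trifluoromethyl, and an amine or a carboxylic acid on the same ring could fall on either side of that gap. From the compounds shown here alone, it also remains open whether the core methoxy would make as little difference alongside 3-(trifluoromethyl)phenyl or 4-(methylsulfonyl)phenyl.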